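Benzoyloxy on the saturated ring carbon: cytotoxicity outlook

This account rests on a few compounds, and the source may have more. Where it says the series, first, only, none or still open, it means among the compounds named here.

Compound 2 `CN1CCc2cc(OCc3ccc(-c4ccccc4)cc3)ccc2C1` gives 16500 nM in an ADME assay on Vero cells (Chlorocebus sabaeus) for cytotoxicity, read by sulforhodamine B assay, with a stated time of 72 h (on this read-out higher numbers stand for weaker inhibition and lower numbers for stronger inhibition), the lowest of the two numbers measured; its nearest neighbour is compound 1 `CN1Cc2ccc(OCc3ccc(-c4ccccc4)cc3)cc2[C@@H](O)C1`, which in this assay gives 23000 nM, and the two lie within the scatter of each other. For the measured compounds named here, the only measured step, a 1.4-fold lower number from compound 1 to compound 2 (0.14 log units; within the scatter), concerns the same saturated ring carbon and shows no movement beyond the scatter. Compound 3 `CN1Cc2ccc(OCc3ccc(-c4ccccc4)cc3)cc2[C@@H](OC(=O)c2ccccc2)C1` carries benzoyloxy in place of hydrogen on a saturated ring carbon. Going by the values given here, no measured step covers entry of a benzoyloxy group, so the only bearing evidence is the hydrogen-for-hydroxy step, which was flat. On that basis the step is expected to be modest, leaning toward a somewhat lower number, as a 1.7-fold lower number from compound 2 to compound 3 (0.22 log units; within the scatter), without confidence that it clears the scatter. Compound 3 is therefore estimated at 10000 nM in this assay, with a range from 3000 nM to 30000 nM.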

Compound 3, half-maximal inhibitory concentration: 10500 nM
Estimate against measurement, compound 3: 1.1-fold (0.02 log units) below, within the range that was stated.
By their numbers in this assay, from the lowest: compounds 3, 2 and 1 (each within the scatter of the next, the first and the last beyond it).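

In this assay, the saturated ring carbon two ring bonds from the ring nitrogen carries a benzoyloxy group, with its six-membered aromatic ring, without movement beyond the scatter relative to hydrogen (a 1.6-fold lower number from compound 2 to compound 3 (0.20 log units; within the scatter)). Benzoyl in place of hydrogen on the oxygen at that carbon gives the only step in the series that lies beyond the scatter, and it is a modest one (a 2.2-fold lower number from compound 1 to compound 3 (0.34 log units; beyond the scatter)). No measurement on these compounds offers an explanation for either step.

The compounds shown leave open whether a shorter acetyl ester, a carboxylic acid or an amine at this carbon would give a number in the same region. They also leave open how the opposite configuration at this carbon would read.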